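Methyl to ethyl on the aryl substituent of compound 1

The source may hold more compounds than are shown below. What is called first, only, known or untested is meant among the compounds shown, and "the series" means these compounds.

Compound 1 `Cc1cccc(N2CCCC(=O)N2)c1` is the anchor of this small series. In an assay on isolated protein for inhibition of Polyunsaturated fatty acid 5-lipoxygenase (Homo sapiens) (on this read-out lower numbers stand for stronger inhibition and higher numbers for weaker inhibition), compound 1 gives 3400 nM, the lowest of the two numbers recorded so far. Among the compounds with values here, the only other measured member, compound 2 `Cc1ccc(N2CCCC(=O)N2)cc1`, carries its methyl on a different position of the aromatic ring and in this assay compound 2 gives 277000 nM, a far higher number that lies well beyond the scatter of repeated measurements. Within the data shown here, no pair differing in a single place has been measured against each other, so no step size is established.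

Compound 3 `CCc1cccc(N2CCCC(=O)N2)c1` extends compound 1 by one carbon: methyl in place of hydrogen on a saturated chain carbon bound to an aromatic carbon. Cut one bond further out, the change reads methyl to ethyl. Among the measured compounds shown here, with no comparable step on record, the expectation rests on the small size of the change alone; no direction can be argued from the data, and a step no larger than the scatter seems most likely. Compound 3 is expected to give 3500 nM, within a range of 1200 nM to 10000 nM. The expected step is a 1.0-fold higher number from compound 1 to compound 3 (0.01 log units; within the scatter), none beyond the scatter.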

Compound 3, half-maximal inhibitory concentration: 3000 nM
Compound 3: middle estimate off by 1.2-fold (0.07 log units), on the high side, and the stated range covers the measured number.
By their numbers in this assay, from the lowest: compounds 3 and 1 (each within the scatter of the next); then compound 2.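

In this assay, within the data shown here, the change from methyl to ethyl gives a 1.1-fold lower number from compound 1 to compound 3 (0.05 log units; within the scatter), the first step between compounds that differ in one place. The saturated chain carbon bound to an aromatic carbon therefore takes one further carbon with no change beyond the scatter, and ethyl serves as well as methyl on the core of compound 1 in this read-out. No measurement at hand bears on why the added carbon leaves the number where it stands.

From the compounds shown here alone, whether this tolerance continues to a longer chain such as propyl, a branched group such as isopropyl, a ring such as cyclopropyl, or a chain ending in an amine or a carboxylic acid remains open. Also open, going by these compounds, is whether the same change from methyl to ethyl on compound 2 would give a step of similar size, so this single step cannot yet be read as a rule for the series.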